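Fluoro for Nitro on an Aromatic Ring: an Expected Value

The compounds below may be only part of what the source reports. "The series", "measured", "known", "first", "only" and "open" are said of these compounds alone.

compound 1 `CCOC(=O)C1=Cc2ccccc2OC1(OCc1cn(-c2ccc(F)cc2)nn1)C(F)(F)F`: 9100 nM
compound 2 `O=C(O)C1=Cc2ccccc2OC1(OCc1cc(-c2ccc([N+](=O)[O-])cc2)no1)C(F)(F)F`: > 150000 nM
compound 3 `CCOC(=O)C1=Cc2ccccc2OC1(OCc1cc(-c2ccc([N+](=O)[O-])cc2)no1)C(F)(F)F`: > 150000 nM

All three values come from a functional assay on MCF7 cells (Homo sapiens) for inhibition, read by MTT assay, with a stated time of 24 h; a lower number here means a stronger inhibitor, a higher number a weaker inhibitor. Compound 2 stands only at a limit of this assay, and no number is known for it. Compound 3 sits at the same limit, as the limit of > 150000 nM in this assay, at which 2 of the 3 values shown sit, shows. Within the data shown here, the one step between compounds that differ in a single place, a step that the two limits leave unreadable from compound 2 to compound 3, is thus unreadable. Among the measured compounds shown here, compound 1 is the only one with a number, and it differs from compound 3 in two places, not one; their two values show only that compound 1 lies within the measured range while compound 3 does not.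

Compound 4 `O=C(O)C1=Cc2ccccc2OC1(OCc1cc(-c2ccc(F)cc2)no1)C(F)(F)F` differs from compound 2 in one place: fluoro in place of nitro on an aromatic carbon. For the measured compounds named here, no measured step bears on this change, and the comparison of compound 1 with compound 3 carries a second difference as well. Compound 4 is therefore expected to stay near the limit, with the step of an at least 1.2-fold lower number from compound 2 to compound 4 (0.09 log units; that floor lies within the scatter) taken as the estimate. The value estimated for compound 4 is 120000 nM, within 30000 nM to 400000 nM.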

Compound 4, half-maximal inhibitory concentration: 64200 nM
Beside the measured number, compound 4's estimate is 1.9-fold (0.27 log units) above it; low and high end bracket the measured number.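

In this assay, fluoro in place of nitro on the aromatic carbon gives an at least 2.3-fold lower number from compound 2 to compound 4 (0.36 log units; beyond the scatter), and this single change is enough to bring the compound off the limit. Compound 4, at 64200 nM, is the only compound with the free carboxylic acid on the shared core to give a number, so a position para to a large group is shown to matter for this read-out in a comparison with one difference only. Compound 2 stands at a limit, so the size of the step is a floor and not a measured gap: the limit of > 150000 nM in this assay, at which 2 of the 4 values shown sit.

On these data alone, whether an amine or a chloro in the same place would lower the number further remains open. The step for ethyl in place of the acid hydrogen cannot be read, so what that change does alongside the 4-fluorophenyl group is also unknown.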